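The source may report more compounds than this note shows. Statements on the series, on what has been measured and on what is new or still open speak of the compounds shown alone.

Compound 3 `CCCCNS(=O)(=O)c1ccc(Nc2ncc3c(n2)N(C2CCCC2)[C@H](CC)C(=O)N3C)cc1` gives 225 nM in a functional assay on Huh-7 cells (Homo sapiens) for antiproliferative activity, read by CCK-8 assay, with a stated time of 72 h (a higher number here means a weaker inhibitor of growth, a lower number a stronger inhibitor of growth), the lowest of the three numbers recorded so far. Compound 1 `CC[C@@H]1C(=O)N(C)c2cnc(Nc3ccc(S(=O)(=O)NCCO)cc3)nc2N1C1CCCC1` lies within the usual scatter of it, the step being a 1.2-fold lower number from compound 1 to compound 3 (0.09 log units; within the scatter), and compound 1 gives 278 nM. Compound 2 `CC[C@@H]1C(=O)N(C)c2cnc(Nc3ccc(S(N)(=O)=O)cc3)nc2N1C1CCCC1` gives 1300 nM and stands clearly apart. Compound 4 `CC[C@@H]1C(=O)N(C)c2cnc(Nc3ccc(S(=O)(=O)NC)cc3)nc2N1C1CCCC1` differs from compound 3 in one place: hydrogen in place of propyl on a saturated chain carbon bound to a sulfonamide nitrogen.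

For the measured compounds named here, two measured steps bear on this change. The step of a 5.8-fold lower number from compound 2 to compound 3 (0.76 log units; beyond the scatter) shows that a butyl group on the sulfonamide nitrogen in place of hydrogen brought a modest lowering of the number, and the step of a 4.7-fold higher number from compound 1 to compound 2 (0.67 log units; beyond the scatter) shows that taking away the 2-hydroxyethyl group from the same nitrogen raised it by a similar modest amount. A methyl group on the sulfonamide nitrogen stands between hydrogen and butyl, so part of the gain seen in compound 3 is expected to be given back, but not all of it. For compound 4 the expected step is a 2.0-fold higher number from compound 3 to compound 4 (0.30 log units; within the scatter), which would leave it above the scatter of compound 3 yet well short of compound 2. Compound 4 is therefore estimated at 450 nM, with a range from 200 nM to 1100 nM.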

Compound 4, concentration for 50% growth inhibition: 99 nM
Beside the measured number, compound 4's estimate is 4.5-fold (0.66 log units) above it; measured number below the stated range.
By their numbers in this assay, from the lowest: compound 4; then compounds 3 and 1 (each within the scatter of the next); then compound 2.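

In this assay the methyl group on the sulfonamide nitrogen does not fall midway from hydrogen to butyl: the step (a 13-fold lower number from compound 2 to compound 4 (1.12 log units; beyond the scatter)) is large, and compound 4 stands beyond the scatter of all three other compounds as the strongest inhibitor of growth shown here. Shortening the chain from butyl to methyl gives (a 2.3-fold lower number from compound 3 to compound 4 (0.36 log units; beyond the scatter)), so across hydrogen, methyl and butyl the number does not fall steadily as the group on this nitrogen grows, with compound 3 going against any such trend. The 2-hydroxyethyl group of compound 1 also gives way to methyl (a 2.8-fold lower number from compound 1 to compound 4 (0.45 log units; beyond the scatter)), which places methyl ahead of both longer groups, while compound 1 and compound 3 remain within the scatter of each other. Nothing given here accounts for this order of the groups.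

The compounds shown leave open how the number changes from methyl to butyl, since neither an ethyl nor a propyl group on the sulfonamide nitrogen stands among them. Also open, as far as these compounds go, is how a second methyl group on that nitrogen, a cyclopropyl group or a chain ending in an amine would read.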